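Sulfur-linked phenyl group change on the shared core

The source may hold more compounds than are shown below. What is called first, only, known or untested is meant among the compounds shown, and "the series" means these compounds.

Measured so far in a functional assay on MT4 cells (Homo sapiens) for inhibition (on this read-out lower numbers stand for stronger inhibition and higher numbers for weaker inhibition), are two compounds.
- Compound 1 `[O-][S+](Cc1[nH]c2ccccc2c1Sc1ccccc1)c1ccccc1` gives 400 nM
- Compound 2 `[O-][S+](Cc1[nH]c2ccc(Cl)cc2c1Sc1ccccc1)c1ccccc1` gives 800 nM

Compound 1 and compound 2 lie within the scatter of each other, so compound 1 does not stand apart on these numbers. The next compound is compound 3 `[O-][S+](Cc1[nH]c2ccccc2c1[S+]([O-])c1ccccc1)c1ccccc1`, which keeps the core of compound 1. The change is a group of 8 heavy atoms (6 carbon, 1 oxygen, 1 sulfur; one six-membered aromatic ring of carbon only) in place of a group of 7 heavy atoms (6 carbon, 1 sulfur; one six-membered aromatic ring of carbon only), on an aromatic carbon. Phenylsulfanyl leaves, and a group with no common name enters, on an aromatic carbon of a five-membered aromatic ring with 1 nitrogen.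

Among the compounds with values here, the only measured step is a 2.0-fold higher number from compound 1 to compound 2 (0.30 log units; within the scatter) and lies within the scatter. It concerns chloro in place of hydrogen, not the group changed here, so it gives only weak guidance. The data hold no direct measure of this change, and the direction remains uncertain. A modest move toward a higher number in this assay is the cautious expectation for a change at a new place. The expected size is a 3.8-fold higher number from compound 1 to compound 3 (0.57 log units; beyond the scatter) as estimated. For compound 3 the estimate is 1500 nM, with an expected range of 300 nM to 8000 nM.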

Compound 3, concentration for 95% inhibition: > 3000 nM
Compound 3 gave a limit, no number (the forecaster's own chance of this, stated with the estimate: 15%); middle value at least 2.0-fold (0.30 log units) away from the limit.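

In this assay compound 3 stands as a limit and not as a number: the limit of > 3000 nM in this assay, at which 1 of the 3 values shown sits.

Even so, the oxygen-bearing group in place of phenylsulfanyl gives an at least 7.5-fold higher number from compound 1 to compound 3 (0.87 log units; beyond the scatter), the first step in the series beyond the scatter, whereas the chloro change gives a 2.0-fold higher number from compound 1 to compound 2 (0.30 log units; within the scatter), which stays within it. The read-out therefore responds to a change at this aromatic carbon, two ring bonds from the ring nitrogen, even though the phenyl ring stays in place and the counted hydrogen-bond donors and acceptors and the net charge are the same for the leaving and entering groups.

Only one replacement at this place is shown, so the compounds cannot tell whether the weaker read-out belongs to this particular group or would also follow from other links between the shared core and the phenyl ring, such as a sulfonyl, a methylene or an amine. Going by these compounds, how far compound 3 lies past its limit also stays open, and with it the full size of the step.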